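The source may report more compounds than this note shows. Statements on the series, on what has been measured and on what is new or still open speak of the compounds shown alone.

Three compounds were tested in a functional assay on HCC 2998 cells (Homo sapiens) for cytotoxicity, read by sulforhodamine B assay, with a stated time of 48 h, tested at 100 uM; on this read-out lower numbers stand for a stronger effect and higher numbers for a weaker effect at the one concentration tested. Compound 1 `COc1ccc(-c2cc(/C=C/C(=O)c3ccc(N)cc3)[nH]n2)cc1` gives -93%, compound 2 `COc1ccc(-c2cc(/C=C/C(=O)c3ccc(N)cc3)[nH]n2)cc1OC` gives -91%, and compound 3 `COc1cc(C(=O)/C=C/c2cc(-c3cc(OC)c(OC)c(OC)c3)n[nH]2)cc(OC)c1OC` gives -89%; all three numbers lie within the scatter of one another. Among the compounds with values here, the one counted step, a number 2 percentage points lower from compound 2 to compound 1 (within the scatter), comes from the change (hydrogen in place of methoxy on an aromatic carbon). How the core of compound 3 differs from that of compound 2 is not broken down here. Compound 4 `COc1ccc(-c2cc(/C=C/C(=O)c3cc(OC)c(OC)c(OC)c3)[nH]n2)cc1OC` is not yet measured in this assay; it arises from compound 3 by hydrogen in place of methoxy on an aromatic carbon, the same kind of change as from compound 2 to compound 1, though here the place is also meta to a methoxy group. Because a number 2 percentage points lower from compound 2 to compound 1 (within the scatter) stayed within the scatter, the step is expected to be small, a number 1 percentage points higher from compound 3 to compound 4 (within the scatter), and compound 4 is expected to give about -88%, between -95% and -78%.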

Compound 4, a percentage reported as activity, at one concentration (the size of the read-out at that concentration, not a potency): -82%
Estimate against measurement, compound 4: 6 percentage points below; measured number inside the range.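

In this assay, hydrogen in place of methoxy on an aromatic carbon gave a number 7 percentage points higher from compound 3 to compound 4 (within the scatter), and the two cores on which this change is seen cannot be told apart by the size of its step: the same change on two cores in this assay, a number 2 percentage points lower (within the scatter) from compound 2 to compound 1 and a number 7 percentage points higher (within the scatter) from compound 3 to compound 4, 9 percentage points apart, within the scatter of two such steps. Within these two pairs, then, the change carried from one core to the other without a step that stands clear of the scatter. This does not show that the two steps are identical or that the change would stay small on a further core: only two pairs are shown, each at the one concentration tested.

The compounds shown leave open how a hydroxy group, a fluorine atom or a longer ethoxy chain would compare with methoxy in this place. They also leave open how a carboxylic acid on either core would read in this assay.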